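Amino for hydrogen on the core of compound 2

A few compounds are considered here, and "the series" means these few. Any claim that something is new, unique, unknown or untested is made for them only; others in the source may bear on it.

Compound 1 `ClCc1ccccc1Cn1cnc2c(Cl)nc(Cl)nc21` gives 420 nM in a functional assay on SK-MEL-5 cells (Homo sapiens) for cytotoxicity, read by sulforhodamine B assay, with a stated time of 48 h; a lower number here means a stronger inhibitor of growth, a higher number a weaker inhibitor of growth. Compound 2 `ClCc1ccccc1Cn1cnc2c(Cl)ncnc21` gives 1410 nM in this assay, and compound 3 `ClCc1cccc(Cn2cnc3ncnc(Cl)c32)c1` gives 4670 nM. Compound 2 thus stands second highest of the three numbers, nearest compound 3 and furthest from compound 1. Among the measured compounds shown here, the only single-point step known, a 3.4-fold higher number from compound 1 to compound 2 (0.53 log units; beyond the scatter), concerns the same aromatic carbon that compound 4 `Nc1nc(Cl)c2ncn(Cc3ccccc3CCl)c2n1` alters: amino in place of hydrogen on an aromatic carbon. For the measured compounds named here, that step shows that a substituent at this carbon moves the number modestly beyond the scatter, but an amino group is not a chloro, and no other step bears on the change. A modest lowering is expected, a 1.6-fold lower number from compound 2 to compound 4 (0.19 log units; within the scatter), with wide uncertainty in either direction. Compound 4 is estimated at 900 nM, within a range of 250 nM to 3500 nM.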

Compound 4, concentration for 50% growth inhibition: 8510 nM
Compound 4: middle estimate off by 9.5-fold (0.98 log units), on the low side, and the stated range ends below it.
By their numbers in this assay, from the lowest: compound 1; then compound 2; then compounds 3 and 4 (each within the scatter of the next).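

In this assay, amino at this aromatic carbon between two ring nitrogen atoms gives a change opposite in direction to chloro: hydrogen to amino raises the number (a 6.0-fold higher number from compound 2 to compound 4 (0.78 log units; beyond the scatter)), and chloro to amino raises it further (a 20-fold higher number from compound 1 to compound 4 (1.31 log units; beyond the scatter)). Across compounds 1, 2 and 4, a group at this carbon therefore does not by itself lower the number; the outcome depends on which group enters. Nothing at hand accounts for this difference.

On these data alone, whether a methylamino or methoxy group at this carbon follows amino or chloro remains open. So does whether amino has the same effect on the core of compound 3.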